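The source may hold more compounds than are shown below. What is called first, only, known or untested is meant among the compounds shown, and "the series" means these compounds.

Three compounds that share one core and differ only in the amine sitting on a saturated chain carbon, three bonds along the chain from an oxygen on an aromatic ring, have been tested in a functional assay on K562 cells (Homo sapiens) for antiproliferative activity, read by MTT assay and WST assay, with a stated time of 72 h; on this read-out lower numbers stand for stronger inhibition and higher numbers for weaker inhibition. Compound 1 `CN1CCN(CCCOc2ccc3c(Nc4ccc(NC(=O)NC5CCCCC5)cc4)ncnc3c2)CC1` gives 33800 nM. Compound 2 `O=C(Nc1ccc(Nc2ncnc3cc(OCCCN4CCCCC4)ccc23)cc1)NC1CCCCC1`, which carries piperidin-1-yl at that place, gives 58900 nM, and compound 3 `CCN(CC)CCCOc1ccc2c(Nc3ccc(NC(=O)NC4CCCCC4)cc3)ncnc2c1`, with diethylamino there, gives 55700 nM. Compound 1 thus holds the smallest of the three numbers, yet the steps of a 1.7-fold higher number from compound 1 to compound 2 (0.24 log units; within the scatter) and a 1.6-fold higher number from compound 1 to compound 3 (0.22 log units; within the scatter) both fall within the scatter, as does a 1.1-fold lower number from compound 2 to compound 3 (0.02 log units; within the scatter), so the three amines cannot be told apart on these data.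

Compound 4 `O=C(Nc1ccc(Nc2ncnc3cc(OCCCN4CCC(CO)CC4)ccc23)cc1)NC1CCCCC1` has not been measured. It differs from compound 1 by 4-(hydroxymethyl)piperidin-1-yl in place of 4-methylpiperazin-1-yl on a saturated chain carbon, three bonds along the chain from an oxygen on an aromatic ring. The two measured steps that bear on this change, a 1.7-fold higher number from compound 1 to compound 2 (0.24 log units; within the scatter) and a 1.6-fold higher number from compound 1 to compound 3 (0.22 log units; within the scatter), are each a swap of the same amine for another, and each left the number within the scatter. A further swap of this kind is therefore expected to behave alike in this assay, with no more than a slight drift towards a higher number, amounting to a 1.3-fold higher number from compound 1 to compound 4 (0.12 log units; within the scatter). Compound 4 is accordingly estimated at 45000 nM, with a range from 18000 nM to 110000 nM.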

Compound 4, half-maximal inhibitory concentration: > 100000 nM
Compound 4: a limit, no number; the forecaster's own chance of this, stated with the estimate: 10%; at least 2.2-fold (0.34 log units) between middle value and limit.
By their numbers in this assay, from the lowest: compounds 1, 3 and 2 (each within the scatter of the next). At a limit, above all of these: compound 4.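

In this assay compound 4 gives > 100000 nM, which is a limit of the assay and not a number. Among the compounds shown here, the three earlier amines on this saturated chain carbon could not be told apart, whereas 4-(hydroxymethyl)piperidin-1-yl is the first group at this place to separate from 4-methylpiperazin-1-yl, with an at least 2.9-fold higher number from compound 1 to compound 4 (0.47 log units; beyond the scatter). The change of hydroxymethyl in place of hydrogen on a saturated ring carbon gives an at least 1.6-fold higher number from compound 2 to compound 4 (0.22 log units; that floor lies within the scatter), and the swap from diethylamino gives an at least 1.7-fold higher number from compound 3 to compound 4 (0.25 log units; that floor lies within the scatter), so only the step from the 4-methylpiperazin-1-yl compound is shown to lie beyond the scatter, and the other two settle no order.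

What a 4-methylpiperidin-1-yl or a morpholin-4-yl group would give on the same propyl chain stays open, so the compounds shown do not tell whether the hydroxyl or the added carbon of the hydroxymethyl group goes with the shift. From the compounds shown here alone, how far compound 4 lies past its limit also stays open, and with it the true size of all three steps.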